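Adding a bromo to compound 2

A few compounds are considered here, and "the series" means these few. Any claim that something is new, unique, unknown or untested is made for them only; others in the source may bear on it.

In an ADME assay on BAEC cells (Bos taurus) for cytotoxicity, read by MTT assay, with a stated time of 2 days (a lower number here means a stronger inhibitor, a higher number a weaker inhibitor), compound 1 `COC1=C(Br)C(=O)[C@]2(C=C1Br)CO2` gives 161000 nM, a high number that marks a weak effect on the cells. Compound 2 `O=C1C=CC(Br)=C[C@]12CO2` has no exact number in this assay. Its result is a limit, > 25000 nM.

Compound 3 `O=C1C(Br)=CC(Br)=C[C@]12CO2` has not yet been measured. It differs from compound 2 in one place: bromo in place of hydrogen on a double-bonded ring carbon. Among the measured compounds shown here, no pair of measured compounds shows what this swap does in this assay, so its size can only be judged roughly. For the measured compounds named here, the one exact number available is for compound 1, at 161000 nM, and it suggests that a weak result is again the likely outcome for this family. A modest step is therefore expected, with the direction, if any, towards a higher number. The expected change is a step that the limit leaves unreadable from compound 2 to compound 3, though this remains an uncertain estimate. Compound 3 is estimated at 60000 nM, with an expected range from 20000 nM to 180000 nM.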

Compound 3, half-maximal inhibitory concentration: 12000 nM
Estimate against measurement, compound 3: 5.0-fold (0.70 log units) above; the whole stated range lies above it.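

In this assay, bromo in place of hydrogen on this double-bonded ring carbon gives an at least 2.0-fold lower number from compound 2 to compound 3 (0.31 log units; beyond the scatter), so this swap moves the number down, towards a stronger effect on the cells, and not up. A second change, hydrogen in place of methoxy on a double-bonded ring carbon, goes with a 13-fold lower number from compound 1 to compound 3 (1.13 log units; beyond the scatter), which shows that the weak result of compound 1 does not hold for every member of this small family. The first of these steps can be read only as a minimum, and its true size stays unknown because compound 2 carries only a limit: the limit of > 25000 nM in this assay, at which 1 of the 3 values shown sits.

What the compounds shown leave open is whether another group on the first ring carbon, such as chloro or an amine, would lower the number as bromo does. On these data alone, it also remains open whether a longer chain in place of methoxy, such as ethoxy, would keep the number high, as it stands for compound 1, or bring it down towards that of compound 3.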